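Swapping the thioether aryl group on a benzamide

This account rests on a few compounds, and the source may have more. Where it says the series, first, only, none or still open, it means among the compounds named here.

Compound 2 `COc1ccc(SCc2ccc(C(=O)Nc3ccccc3N)cc2)cc1` is the highest of the three measured compounds in a functional assay on SMMC-7721 cells (Homo sapiens) for inhibition, read by CCK-8 assay, with a stated time of 72 h, tested at 8 uM (on this read-out higher numbers stand for more inhibition of growth at the one concentration tested and lower numbers for less inhibition of growth), where compound 2 gives 80.1%. Compound 1 `Nc1ccccc1NC(=O)/C=C/c1ccc(CSc2ccc(F)cc2)cc1` gives 15.4% and compound 3 `Nc1ccccc1NC(=O)/C=C/c1ccc(CSc2cccc(F)c2)cc1` gives 8.25%; both are beyond the scatter from compound 2. Compound 4 `Nc1ccccc1NC(=O)c1ccc(CSc2cccc(F)c2)cc1` has not yet been measured and differs from compound 2 in one place: 3-fluorophenyl in place of 4-methoxyphenyl on a sulfur.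

Among the measured compounds shown here, the only measured step that touches the aryl group on the sulfur is a number 7.2 percentage points lower from compound 1 to compound 3 (within the scatter), and it stayed within the scatter, but it compares two fluorophenyl groups on a different core. For the measured compounds named here, no measured pair separates the methoxyphenyl from a fluorophenyl on the core of compound 2, and compound 1 and compound 3 differ from compound 2 in two places at once, so how much of their gap to compound 2 belongs to the aryl group is unknown. Compound 4 is therefore expected to lose some ground, with the step estimated as a number 30.1 percentage points lower from compound 2 to compound 4 (beyond the scatter). The estimate for compound 4 is 50%, within a wide range from 15% to 82%.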

Compound 4, percent growth inhibition at one concentration: 83%
Estimate against measurement, compound 4: 33 percentage points below; measured number outside the range, above it.
By their numbers in this assay, from the lowest: compounds 3 and 1 (each within the scatter of the next); then compounds 2 and 4 (each within the scatter of the next).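

On the core of compound 2, the aryl group on the sulfur can be exchanged with no change beyond the scatter in this assay, since 3-fluorophenyl in place of 4-methoxyphenyl gives a number 2.9 percentage points higher from compound 2 to compound 4 (within the scatter) and the high number holds. With the same 3-fluorophenyl on the sulfur, compound 3 gives 8.25% while compound 4 gives 83% on its own core, so that aryl group alone does not set the low number of compound 3. Nothing measured here explains why the 4-methoxyphenyl and 3-fluorophenyl compounds read alike.

The compounds shown leave open whether an amine or a carboxylic acid on this aryl ring would hold the number, and whether a longer chain on the sulfur would do so. They also leave open whether compound 2 and compound 4 would still read alike at a lower concentration.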